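The compounds below may be only part of what the source reports. "The series", "measured", "known", "first", "only" and "open" are said of these compounds alone.

Compound 1 `CCCn1c(=O)[nH]c2nc(-c3ccc(S(=O)(=O)N4CCN(c5ccc(F)cc5)CC4)cc3)[nH]c2c1=O` and compound 2 `CCCn1c(=O)[nH]c2nc(-c3ccc(S(=O)(=O)N4CCN(c5cccc(Br)c5)CC4)cc3)[nH]c2c1=O` have been measured in an assay on CHO cells for displacement of a labelled ligand from adenosine receptor A3 (Homo sapiens), read by scintillation counting, with a stated time of 45 min, in the presence of a further agent that is not named here; on this read-out higher numbers stand for weaker inhibition and lower numbers for stronger inhibition. In this assay compound 1 gives > 1000 nM, a limit of the assay rather than a number. Compound 2 gives > 1000 nM in this assay, likewise a limit. Both results sit at the limit of > 1000 nM in this assay, at which 2 of the 2 values shown sit, so compound 2 stands at the limit and the step that the two limits leave unreadable from compound 1 to compound 2 cannot be read. Compound 3 `CCCn1c(=O)[nH]c2nc(-c3ccc(S(=O)(=O)N4CCN(c5cccc(F)c5)CC4)cc3)[nH]c2c1=O` differs from compound 2 by fluoro in place of bromo on an aromatic carbon. Among the compounds with values here, because both measured values rest on (the limit of > 1000 nM in this assay, at which 2 of the 2 values shown sit), no measured step gives a size for this change. Compound 3 is therefore expected to remain near the limit, with a step that the limit leaves unreadable from compound 2 to compound 3 not beyond the scatter. The estimate for compound 3 in this assay is 3000 nM, ranging from 1000 nM to 10000 nM.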

Compound 3, inhibition constant: > 1000 nM
Compound 3: a limit, no number (the forecaster's own chance of this, stated with the estimate: 80%); the middle value lies beyond the limit too.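

No step among compound 1, compound 2 and compound 3 can be read, since all three results are limits and not numbers: the limit of > 1000 nM in this assay, at which 3 of the 3 values shown sit.

The compounds shown leave open how strong the inhibition by any of them is, and whether changing the group on the phenyl ring or its place makes any difference.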